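This account rests on a few compounds, and the source may have more. Where it says the series, first, only, none or still open, it means among the compounds named here.

Three members of one series of cinnamoyl hydrazides have been tested in a functional assay on NCI-H1299 cells (Homo sapiens) for antiproliferative activity, read by MTT assay, with a stated time of 24 h (on this read-out higher numbers stand for weaker inhibition and lower numbers for stronger inhibition), and a fourth is still waiting for its number.

Compound 1, with the structure `COc1ccc(C(=O)NNC(=O)/C=C/c2ccc(O)cc2)cc1`, gives 6640 nM in this assay. Compound 2, with the structure `O=C(/C=C/c1ccc(O)cc1)NNC(=O)c1ccc(O)cc1`, differs from it in a single spot, (hydrogen in place of methyl on an oxygen on an aromatic ring), and gives 5470 nM. Between them the change made a 1.2-fold lower number from compound 1 to compound 2 (0.08 log units; within the scatter), so the two numbers say the same thing about how strongly the cells are held back.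

Compound 3, with the structure `COc1ccc(C(=O)NNC(=O)/C=C/c2cc(OC)c(O)c(OC)c2)cc1`, gives 7450 nM. It carries a different core from compound 1; the difference between the two cores is not broken down here. Its number sits among the other two, and none of the three stands apart.

Compound 4, with the structure `COc1cc(/C=C/C(=O)NNC(=O)c2ccc(O)cc2)cc(OC)c1O`, is made from compound 3 by hydrogen in place of methyl on an oxygen on an aromatic ring. This is the same change that turned compound 1 into compound 2, and it sits in the same surroundings: on an oxygen on an aromatic ring whose other neighbours are aromatic carbon. Because that earlier change produced a 1.2-fold lower number from compound 1 to compound 2 (0.08 log units; within the scatter), the expected step here is a 1.2-fold lower number from compound 3 to compound 4 (0.07 log units; within the scatter), a shift that should not lift compound 4 out of the band the other three occupy. On this basis compound 4 is estimated to give about 6300 nM in this assay, with a plausible range from 3500 nM to 11000 nM.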

Compound 4, half-maximal inhibitory concentration: 8710 nM
For compound 4 the middle estimate is 1.4-fold (0.14 log units) below the measured one; measured number inside the range.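

Replacing the methyl with hydrogen on the oxygen of the aromatic ring gives, in this assay, a 1.2-fold higher number from compound 3 to compound 4 (0.07 log units; within the scatter), so on this second core the methoxy to hydroxy change again makes no difference that repeated measurements could separate from scatter. The two cases agree, and on these two cores the 4-methoxyphenyl to 4-hydroxyphenyl change carries over as a change that leaves the number in place: the same change on two cores in this assay, a 1.2-fold lower number (0.08 log units; within the scatter) from compound 1 to compound 2 and a 1.2-fold higher number (0.07 log units; within the scatter) from compound 3 to compound 4, 1.4-fold (0.15 log units) apart, within the scatter of two such steps. This is a statement about two cores in one cell assay only: it does not show that the change would stay silent on any other core or in any other assay, and steps this small cannot reveal whether a slight real effect lies hidden within the scatter of either one.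

The compounds shown leave open what a different group on that oxygen or in place of it would do, for example a longer chain such as ethoxy, an amine or a carboxylic acid. They also leave open whether any single change in this series can shift the number by more than the scatter, which is what a clear link between structure and effect on these cells would need.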